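The source may report more compounds than this note shows. Statements on the series, on what has been measured and on what is new or still open speak of the compounds shown alone.

Measured compounds:
- Compound 1, `COc1c(OCCCCN2CCN(C)CC2)cc(O)c2c(=O)cc(-c3ccc([N+](=O)[O-])cc3)oc12`: 2620 nM
- Compound 2, `CN(C)CCCOc1c(OCc2ccccc2)cc(O)c2c(=O)cc(-c3ccccc3)oc12`: 4950 nM

In a functional assay on HepG2 cells (Homo sapiens) for cytotoxicity, read by MTT assay, with a stated time of 72 h (on this read-out higher numbers stand for weaker inhibition and lower numbers for stronger inhibition), compound 2 gives 4950 nM, and compound 1 gives 2620 nM. Among the two numbers available, compound 2 stands alongside compound 1, the two values lying within the usual scatter of each other, so no order between them can be read. Compound 3, `O=c1cc(-c2ccccc2)oc2c(OCCCCN3CCCC3)c(OCc3ccccc3)cc(O)c12`, has not yet been tested in this assay. It differs from compound 2 in one place: (pyrrolidin-1-yl)methyl in place of dimethylamino on a saturated chain carbon, three bonds along the chain from an oxygen on an aromatic ring. Among the measured compounds shown here, no measured pair shows the effect of this change, so the expectation rests on the change alone, and a step of no more than the scatter, in no clear direction, is expected from compound 2 to compound 3, a 1.1-fold lower number from compound 2 to compound 3 (0.04 log units; within the scatter). Compound 3 is accordingly estimated to give 4500 nM in this assay, with a plausible range from 1800 nM to 11000 nM.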

Compound 3, half-maximal inhibitory concentration: 4660 nM
Compound 3: the middle estimate sits 1.0-fold (0.02 log units) below what was measured; measured number inside the range.
By their numbers in this assay, from the lowest: compounds 1, 3 and 2 (each within the scatter of the next).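

Among the compounds shown here, the only pair here that differs in one place shows that going from 3-(dimethylamino)propyl to 4-(pyrrolidin-1-yl)butyl gives a 1.1-fold lower number from compound 2 to compound 3 (0.03 log units; within the scatter) in this assay, so this read-out does not separate the two groups. At this place, on a saturated chain carbon, three bonds along the chain from an oxygen on an aromatic ring, a five-membered non-aromatic ring can enter with the chain lengthened and no order between the two compounds can be read. Nothing available speaks to why the two numbers stay together.

This single step changes the chain and the amine together, so the compounds shown do not tell the two apart; 3-(pyrrolidin-1-yl)propyl or 4-(dimethylamino)butyl would do so. Also open, on these data alone, is how a morpholine, a piperidine or a carboxylic acid at the chain end would read.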